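Oxetane in Place of Hydroxyl on the Amide Side Chain

A few compounds are considered here, and "the series" means these few. Any claim that something is new, unique, unknown or untested is made for them only; others in the source may bear on it.

The measured compounds:
- Compound 1, `O=C(NCC1CC1)c1ccc(C#Cc2cccc(F)c2)cn1`: 61.4%
- Compound 2, `CC(C)(O)CNC(=O)c1ccc(C#Cc2cccc(F)c2)cn1`: 61.5%

Both compounds were tested in a functional assay on HEK293 cells for positive allosteric modulation of metabotropic glutamate receptor 5 (Rattus norvegicus), read by fluorescence and calcium flux; on this read-out higher numbers stand for larger maximal responses and lower numbers for smaller maximal responses. Compound 1 gives 61.4%, and compound 2 gives 61.5%. The two numbers lie within the usual scatter of each other, so the step of a number 0.1 percentage points higher from compound 1 to compound 2 (within the scatter) shows no real change: exchanging cyclopropyl for 1-hydroxy-1-methylethyl on a saturated chain carbon bound to an amide-type nitrogen left the largest response where it was. On the numbers shown, compound 2 and compound 1 therefore stand together, neither apart from the other.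

The unmeasured compound 3, `CC1(CNC(=O)c2ccc(C#Cc3cccc(F)c3)cn2)COC1`, differs from compound 2 in one place: 3-methyloxetan-3-yl in place of 1-hydroxy-1-methylethyl on a saturated chain carbon bound to an amide-type nitrogen. Among the measured compounds shown here, the only step that bears on this position is a number 0.1 percentage points higher from compound 1 to compound 2 (within the scatter), which was within the scatter. For the measured compounds named here, with one flat step as the sole guide, no move beyond the scatter is expected in this assay in either direction. Compound 3 is therefore estimated at 60%, within a range from 45% to 75%. This corresponds to an expected step of a number 1.5 percentage points lower from compound 2 to compound 3 (within the scatter).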

Compound 3, largest response reached (reported as efficacy), in percent of the reference or control that the assay uses: 60.4%
Compound 3: the middle estimate sits 0.4 percentage points below what was measured, within the range that was stated.
By their numbers in this assay, from the lowest: compounds 3, 1 and 2 (each within the scatter of the next).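

In this assay, the exchange of 1-hydroxy-1-methylethyl for 3-methyloxetan-3-yl gives a number 1.1 percentage points lower from compound 2 to compound 3 (within the scatter) even though the entering group has 0 hydrogen-bond donors where the leaving group has 1, so on this read-out a hydrogen-bond donor is not required on this saturated chain carbon bound to an amide-type nitrogen. Among the compounds shown here, the comparison with the first side chain, a number 1 percentage points lower from compound 1 to compound 3 (within the scatter) as well, completes the set: cyclopropyl, 1-hydroxy-1-methylethyl and 3-methyloxetan-3-yl, with a three-membered carbon ring, no ring, or a four-membered ring holding oxygen, all lie within the scatter of one another, which makes a wider flat picture than the single step seen before. No measurement shown here explains this flat picture.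

From the compounds shown here alone, whether a group of a different kind in this place, such as an amine, a carboxylic acid or a longer chain, would move the response beyond the scatter stays open. The largest response also leaves open how much of each compound is needed to reach it, so these side chains may yet differ in that respect.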